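The source may report more compounds than this note shows. Statements on the series, on what has been measured and on what is new or still open speak of the compounds shown alone.

Working notes on the series. In a functional assay on Jurkat cells (Homo sapiens) for inhibition, with a stated time of 24 h (a higher number here means a weaker inhibitor, a lower number a stronger inhibitor), compound 1 (`O=[N+]([O-])c1cccc(Nc2nnc(-c3c[nH]c4ccccc34)o2)c1`) gives > 100000 nM, which is a limit of the assay and not a number. Compound 2 (`O=[N+]([O-])c1ccc(Nc2nnc(-c3c[nH]c4ccccc34)o2)cc1`) gives 45000 nM, and compound 3 (`Clc1ccc(Nc2nnc(-c3c[nH]c4ccccc34)o2)cc1`) gives 30200 nM. Within the data shown here, compound 3 therefore holds one of only two numbers available, and the single measured step, a 1.5-fold lower number from compound 2 to compound 3 (0.17 log units; within the scatter), is chloro in place of nitro on an aromatic carbon and stays within the scatter.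

Next is compound 4 (`Clc1cccc(Nc2nnc(-c3c[nH]c4ccccc34)o2)c1`): 3-chlorophenyl in place of 4-chlorophenyl on a nitrogen on an aromatic ring, with 3-chlorophenyl in place of 4-chlorophenyl on a nitrogen on an aromatic ring. Among the measured compounds shown here, the one measured step is a different change, so it sets no size for this one. For the measured compounds named here, the only other guide is the limit of > 100000 nM in this assay, at which 1 of the 3 values shown sits. On this thin basis, a small move toward a higher number is expected in this assay, with a real chance of a limit instead of a number. The expected change is a 2.0-fold higher number from compound 3 to compound 4 (0.30 log units; within the scatter). For compound 4 the estimated value is 60000 nM, with an expected range of 25000 nM to 100000 nM.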

Compound 4, half-maximal inhibitory concentration: > 100000 nM
Compound 4: a limit, no number (the forecaster's own chance of this, stated with the estimate: 35%); middle value at least 1.6-fold (0.22 log units) from the limit.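

In this assay, among these compounds, 3-chlorophenyl in place of 4-chlorophenyl on a nitrogen on an aromatic ring gives an at least 3.3-fold higher number from compound 3 to compound 4 (0.51 log units; beyond the scatter), the first step that lies beyond the scatter, so a change of place alone is readable here, where chloro in place of nitro between compound 2 and compound 3 was not. Compound 4 gives > 100000 nM, which is a limit of the assay and not a number, so the step fixes only a smallest size. The step between compound 1 and compound 4 cannot be read, since both are limits, and the limit now takes in more of the series: the limit of > 100000 nM in this assay, at which 2 of the 4 values shown sit.

As far as these compounds go, how far this holds for other groups stays open, since only chloro and nitro appear on this ring. From the compounds shown here alone, whether a methoxy or an amine in place of the chloro of compound 4 would bring back a number in this assay also stays open.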